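The source may hold more compounds than are shown below. What is called first, only, known or untested is meant among the compounds shown, and "the series" means these compounds.

Measured in a toxicity assay on THP-1 cells (Homo sapiens) for cytotoxicity; on this read-out higher numbers stand for an effect only at larger amounts of compound and lower numbers for an effect already at smaller amounts:
- compound 1 `O=C(NCc1ccc(Cl)cc1)c1ncc2cccnc2c1O`: > 50100 nM, a limit
- compound 2 `Cc1n[nH]c(-c2ncc3c(-c4ccccc4C(F)(F)F)ccnc3c2O)n1`: > 50100 nM, a limit
- compound 3 `CNC(=O)c1nc(-c2ccccc2OC)c2cccnc2c1O`: 39800 nM

Compound 1 sits at the limit of > 50100 nM in this assay, at which 2 of the 3 values shown sit. This is a limit and not a number, so it gives no exact starting point.

Compound 4 `COc1ccc(CNC(=O)c2ncc3cccnc3c2O)cc1` has methoxy in place of chloro on an aromatic carbon, para to a large group: methoxy in place of chloro on an aromatic carbon. For the measured compounds named here, no measured pair shows what this swap does in this assay. No step beyond the scatter is therefore expected, although compound 3 at 39800 nM shows that a measured number can occur in this series. The expected change is a number no higher from compound 1 to compound 4 (the limit leaves the size open), which is estimated to stay within the scatter. Compound 4 is expected at 50000 nM, with an estimated range of 22000 nM to 100000 nM.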

Compound 4, half-maximal effective concentration in the THP-1 assay: > 50100 nM
Compound 4 gave a limit, no number; the forecaster's own chance of this, stated with the estimate: 75%; at least 1.0-fold (0.00 log units) between middle value and limit.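

In a physicochemical assay for solubility, measured as kinetic solubility (a higher number here means a more soluble compound, a lower number a less soluble compound), compound 1 gives > 250000 nM, which is a limit and not a number. In the physicochemical assay compound 4 gives > 250000 nM, which is also a limit and not a number. For the compounds shown here, compound 1 and compound 4 also both give limits, not numbers, in the THP-1 assay, and no step between them can be read. On these data alone, whether methoxy in place of chloro on an aromatic carbon changes either read-out stays open.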